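The source may hold more compounds than are shown below. What is called first, only, known or untested is meant among the compounds shown, and "the series" means these compounds.

Measured in a functional assay on A549 cells (Homo sapiens) for inhibition, read by sulforhodamine B assay, with a stated time of 48 h; a higher number here means a weaker inhibitor of growth, a lower number a stronger inhibitor of growth:
- compound 1 `Cc1ccn2c(CN3CCCCC3)c(-c3ccccc3)nc2n1`: 4040 nM
- compound 2 `Oc1ccc(-c2nc3ncccn3c2CN2CCCCC2)cc1`: 6890 nM
- compound 3 `c1ccc(-c2nc3ncccn3c2CN2CCCC2)cc1`: 50 nM

Compound 3 has the lowest of the three numbers, and both other compounds lie well above it, beyond the scatter. The next step leads to compound 4 `c1ccc(-c2nc3ncccn3c2CN2CCCCC2)cc1`. The change is piperidin-1-yl in place of pyrrolidin-1-yl on a saturated chain carbon bound to an aromatic carbon, with piperidin-1-yl in place of pyrrolidin-1-yl on a saturated chain carbon bound to an aromatic carbon.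

Going by the values given here, no measured pair isolates this change. Compound 1 and compound 2 both carry piperidin-1-yl, but each also has a further group that compound 4 lacks, so they offer only indirect guidance. Their values, with compound 1 at 4040 nM and compound 2 at 6890 nM, point towards a weaker growth inhibitor. A rise beyond the scatter is therefore expected, an estimated 12-fold higher number from compound 3 to compound 4 (1.08 log units; beyond the scatter). The uncertainty is wide. For compound 4 the estimated value is 600 nM, with an expected range of 80 nM to 5000 nM.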

Compound 4, concentration for 50% growth inhibition: 260 nM
Compound 4: middle estimate off by 2.3-fold (0.36 log units), on the high side, and the stated range covers the measured number.
By their numbers in this assay, from the lowest: compound 3; then compound 4; then compounds 1 and 2 (each within the scatter of the next).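

In this assay, going by these compounds alone, piperidin-1-yl in place of pyrrolidin-1-yl on a saturated chain carbon bound to an aromatic carbon gives a 5.2-fold higher number from compound 3 to compound 4 (0.72 log units; beyond the scatter), the first direct reading of this change and a sign that this position responds to the amine ring. With piperidin-1-yl held constant, removing the hydroxy group gives a 27-fold lower number from compound 2 to compound 4 (1.42 log units; beyond the scatter) and removing the methyl group gives a 16-fold lower number from compound 1 to compound 4 (1.19 log units; beyond the scatter), so piperidin-1-yl alone does not account for the high numbers of compound 1 and compound 2. No supporting data bear on the cause of any of these steps.

From the compounds shown here alone, whether the hydroxy and methyl groups cost as much alongside pyrrolidin-1-yl remains open. Also open, going by these compounds, is how morpholin-4-yl or an open-chain dimethylamino group would read at this position.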